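The source may report more compounds than this note shows. Statements on the series, on what has been measured and on what is new or still open speak of the compounds shown alone.

In an ADME assay on HUVEC cells (Homo sapiens) for cytotoxicity, read by MTT assay, with a stated time of 2 days (a lower number here means a stronger inhibitor, a higher number a weaker inhibitor), three compounds of a shared core have been tested so far, and none of them gave a number. Compound 1, `O/N=C1/C(c2c[nH]c3ccc(OCc4ccccc4)cc23)=Nc2ccc(OCc3ccccc3)cc21`, reached only a limit of the assay, > 100000 nM. Compound 2, `CC(=O)Nc1ccc2c(c1)/C(=N\O)C(c1c[nH]c3ccc(NC(C)=O)cc13)=N2`, likewise reached only a limit, > 100000 nM. Compound 3, `c1ccc(CO/N=C2/C(c3c[nH]c4ccccc34)=Nc3ccccc32)cc1`, also stands at a limit in this assay, > 100000 nM. Where compound 3 stands is therefore described only by the limit of > 100000 nM in this assay, at which 3 of the 3 values shown sit; no measurable cytotoxicity toward these cells appeared for any of the three within the tested range.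

Compound 4, `Cc1ccc(CO/N=C2/C(c3c[nH]c4ccccc34)=Nc3ccccc32)cc1`, differs from compound 3 in a single place: methyl in place of hydrogen on an aromatic carbon, in words, methyl in place of hydrogen on an aromatic carbon. Among the measured compounds shown here, no step between two measured compounds exists here, so the effect of such a change cannot be read from the data, and the neighbouring compounds give no hint of a number below the limit. The expected step is a number no higher from compound 3 to compound 4 (the limit leaves the size open), which is to say none beyond the scatter. For compound 4 the estimate in this assay is 100000 nM, within a range from 30000 nM to 300000 nM, and most probably the assay will again report only a limit.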

Compound 4, half-maximal inhibitory concentration: > 100000 nM
Compound 4: only a limit was reported; the forecaster's own chance of this, stated with the estimate: 85%; the middle value sits exactly at the limit.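

Compound 3 and compound 4 both stand only at a limit in this assay, so no step can be read between them: the limit of > 100000 nM in this assay, at which 4 of the 4 values shown sit. The compounds shown leave open whether this shared core harms these cells at any measurable concentration, and what the added methyl changes.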